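Adding a fluorine to the benzyl ring of a thiazolidinedione

The source may hold more compounds than are shown below. What is called first, only, known or untested is meant among the compounds shown, and "the series" means these compounds.

Compound 3 `Nc1ccc(/C=C2\SC(=O)N(Cc3ccccc3)C2=O)cc1` is the unsubstituted parent of this small set. In a functional assay on L1210 cells (Mus musculus) for cytotoxicity, read by cell counting, with a stated time of 2 days (a higher number here means a weaker inhibitor, a lower number a stronger inhibitor), compound 3 gives 38000 nM, the second highest of the three numbers, sitting beside compound 1 `Nc1ccc(/C=C2\SC(=O)N(Cc3ccc(Cl)cc3)C2=O)cc1` with 37000 nM, while compound 2 `Nc1ccc(/C=C2\SC(=O)N(Cc3cccc(F)c3)C2=O)cc1` gives 100000 nM. Compound 4 `Nc1ccc(/C=C2\SC(=O)N(Cc3ccc(F)cc3)C2=O)cc1` carries one change: fluoro in place of hydrogen on an aromatic carbon. Two measured steps speak to it. The step of a 1.0-fold higher number from compound 1 to compound 3 (0.01 log units; within the scatter) shows that a halogen on that aromatic carbon hardly matters, while a 2.6-fold lower number from compound 2 to compound 3 (0.42 log units; beyond the scatter) shows a fluoro elsewhere on the ring weakening activity modestly. A fluoro here is therefore expected to give at most a small shift, a 1.2-fold higher number from compound 3 to compound 4 (0.07 log units; within the scatter), toward a slightly weaker compound. Compound 4 is estimated at 45000 nM, between 20000 nM and 110000 nM.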

Compound 4, half-maximal inhibitory concentration: 24000 nM
Compound 4: middle estimate off by 1.9-fold (0.27 log units), on the high side, and the stated range covers the measured number.
By their numbers in this assay, from the lowest: compounds 4, 1 and 3 (each within the scatter of the next); then compound 2.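

In this assay, fluoro on the aromatic carbon para to a large group stays within the scatter of both hydrogen (a 1.6-fold lower number from compound 3 to compound 4 (0.20 log units; within the scatter)) and chloro (a 1.5-fold lower number from compound 1 to compound 4 (0.19 log units; within the scatter)), so these three compounds do not separate at this position. Where the fluorine sits does count, since the 3-fluorophenyl and 4-fluorophenyl compounds lie beyond the scatter of each other (a 4.2-fold lower number from compound 2 to compound 4 (0.62 log units; beyond the scatter)). Nothing given here explains that gap. Going by these compounds, whether a methoxy group or an amine at this position, or a longer chain in place of the benzyl link, would also leave the number unmoved remains open.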